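The source may report more compounds than this note shows. Statements on the series, on what has been measured and on what is new or still open speak of the compounds shown alone.

In a functional assay on SW480 cells (Homo sapiens) for antiproliferative activity, read by MTT assay, with a stated time of 48 h (a higher number here means a weaker inhibitor, a lower number a stronger inhibitor), compound 1 `C=C(CO)C(CCCCC)n1cnc2c(Cl)ncnc21` gives only a limit, > 50000 nM, and not a number. For the measured compounds named here, compound 2 `CCCCCCC(CCO)n1cnc2c(Cl)ncnc21` gives 16700 nM, the only true number so far, so it stands as the single measured point of reference. Compound 3 `C=C(CO)C(CCCCCC)n1cnc2c(Cl)ncnc21` departs from it at one place, with 1-(hydroxymethyl)ethenyl in place of 2-hydroxyethyl on a saturated chain carbon bound to an aromatic nitrogen and a saturated chain carbon. Going by the values given here, no step between measured compounds is available to size this change. The expectation therefore rests on little more than the two readings in this assay. The estimated step of a 1.5-fold higher number from compound 2 to compound 3 (0.18 log units; within the scatter) is expected to be small, leaning toward weaker inhibition, and it may not clear the usual scatter. For compound 3 the expected value is 25000 nM, with an estimated range from 9000 nM to 60000 nM.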

Compound 3, half-maximal inhibitory concentration: 32000 nM
Compound 3: middle estimate off by 1.3-fold (0.11 log units), on the low side, within the range that was stated.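

In this assay, 1-(hydroxymethyl)ethenyl in place of 2-hydroxyethyl on a saturated chain carbon bound to an aromatic nitrogen and a saturated chain carbon now has a measured size, a 1.9-fold higher number from compound 2 to compound 3 (0.28 log units; within the scatter), so this change does not separate the two compounds. Methyl in place of hydrogen on a saturated chain carbon, six bonds along the chain from an aromatic nitrogen and a double-bonded chain carbon, gives an at least 1.5-fold lower number from compound 1 to compound 3 (0.19 log units; that floor lies within the scatter), and this step too leaves the two compounds unseparated. The reading of compound 1 is a limit and not a number, so that step gives only a floor: the limit of > 50000 nM in this assay, at which 1 of the 3 values shown sits.

Still open, going by these compounds, is whether an amine or a carboxylic acid in place of 1-(hydroxymethyl)ethenyl would move the number beyond the scatter. Whether a longer chain would do so is open as well.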